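The compounds below may be only part of what the source reports. "The series", "measured", "known", "first", "only" and "open" are said of these compounds alone.

Of the compounds shown here, three sharing one core have been measured in a functional assay for inhibition, using microsomes, tested at 200 ug/mL; a lower number here means a stronger effect, a higher number a weaker effect of the compound at the concentration tested. Compound 1 `CCOC(=O)C1=C(C)N(c2ccccc2)C=CC1c1ccccc1` gives -37.1%. Compound 2 `CCOC(=O)C1=C(C)N(c2ccc(Cl)cc2)C=CC1c1ccccc1` gives -34.4%. Compound 3 `CC1=C(C(=O)OC(C)(C)C)C(c2ccccc2)C=CN1c1ccccc1` gives -42.1%. On these numbers compound 3 stands alongside the other two: the step of a number 5 percentage points lower from compound 1 to compound 3 (within the scatter) does not reach beyond the scatter, and its gap to compound 2 does not either, so the three values cannot be told apart.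

Compound 4 `CC1=C(C(=O)OC(C)(C)C)C(c2ccccc2)C=CN1c1ccc(Cl)cc1` has not yet been measured. It differs from compound 3 by chloro in place of hydrogen on an aromatic carbon. Going by the values given here, one measured step bears directly on this change: the step of a number 2.7 percentage points higher from compound 1 to compound 2 (within the scatter), which made the same exchange on the same core carrying the ethyl ester. Because that step stayed within the scatter, no shift beyond the scatter is expected for compound 4 either, in neither direction. Compound 4 is therefore estimated at -40%, with a range from -52% to -28%, which means an expected step of a number 2.1 percentage points higher from compound 3 to compound 4 (within the scatter).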

Compound 4, a percentage reported as activity, at one concentration (the size of the read-out at that concentration, not a potency): -26.6%
For compound 4 the middle estimate is 13.4 percentage points below the measured one; the measured number lies above the stated range.
By their numbers in this assay, from the lowest: compounds 3, 1, 2 and 4 (each within the scatter of the next, the first and the last beyond it).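

In this assay, the phenyl to 4-chlorophenyl change on the tert-butyl ester gives a step beyond the scatter, a number 15.5 percentage points higher from compound 3 to compound 4 (beyond the scatter), so chloro at this position can weaken the effect at the concentration tested, which the ethyl ester pair did not show. This does not establish that the change behaves differently on the two esters, as the two steps remain within the scatter of each other: the same change on two cores in this assay, a number 2.7 percentage points higher (within the scatter) from compound 1 to compound 2 and a number 15.5 percentage points higher (beyond the scatter) from compound 3 to compound 4, 12.8 percentage points apart, within the scatter of two such steps With chloro present, the ester exchange also stays within the scatter, a number 7.8 percentage points higher from compound 2 to compound 4 (within the scatter), and it does not separate tert-butyl from ethyl: the same change on two cores in this assay, a number 5 percentage points lower (within the scatter) from compound 1 to compound 3 and a number 7.8 percentage points higher (within the scatter) from compound 2 to compound 4, 12.8 percentage points apart, within the scatter of two such steps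

The compounds shown leave open whether fluoro, methoxy or an amine in place of chloro on this aromatic carbon would shift the number as chloro does. Going by these compounds, how a carboxylic acid in place of the ester would read also remains open.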